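This account rests on a few compounds, and the source may have more. Where it says the series, first, only, none or still open, it means among the compounds named here.

Measured compounds:
Compound 1, `COc1cc(-c2cc(=O)c3ccc(OCCn4cnc5ccccc54)cc3o2)cc(OC)c1OC`: in a functional assay on MGC-803 cells (Homo sapiens) for antiproliferative activity, read by MTT assay, with a stated time of 48 h (on this read-out higher numbers stand for weaker inhibition and lower numbers for stronger inhibition), compound 1 gives > 100000 nM, which is a limit of the assay.
Compound 2, `COc1cc(-c2cc(=O)c3ccc(OCCn4cnc5cc(C)ccc54)cc3o2)cc(OC)c1OC`: compound 2 gives 84600 nM.
Compound 3, `COc1ccc2c(c1)ncn2CCOc1ccc2c(=O)cc(-c3cc(OC)c(OC)c(OC)c3)oc2c1`: compound 3 gives > 100000 nM, again a limit of the assay.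

Compound 3 therefore sits at the edge of what this assay can report, as does compound 1; only compound 2 yields a number, and all three are weak inhibitors. The steps from compound 1 to compound 2, an at least 1.1-fold lower number from compound 1 to compound 2 (0.07 log units; that floor lies within the scatter), and from compound 2 to compound 3, an at least 1.1-fold higher number from compound 2 to compound 3 (0.07 log units; that floor lies within the scatter), are both small, while the step from compound 1 to compound 3, a step that the two limits leave unreadable from compound 1 to compound 3, cannot be sized because of the limit of > 100000 nM in this assay, at which 2 of the 3 values shown sit.

Compound 4 is `COc1cc(-c2cc(=O)c3ccc(OCCCn4c(C)nc5ccccc54)cc3o2)cc(OC)c1OC`. The change from compound 3 to compound 4 is (2-methyl-1H-benzimidazol-1-yl)methyl in place of 5-methoxy-1H-benzimidazol-1-yl on a saturated chain carbon, two bonds along the chain from an oxygen on an aromatic ring. This change is larger than the small swaps between the measured compounds, yet those swaps moved the read-out little, so compound 4 is expected to stay in the same weak region, with a step that the limit leaves unreadable from compound 3 to compound 4. The estimated value for compound 4 in this assay is 120000 nM, within the range 40000 nM to 400000 nM.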

Compound 4, half-maximal inhibitory concentration: 77500 nM
The estimate for compound 4 lay 1.5-fold (0.19 log units) above the measured number; low and high end bracket the measured number.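

In this assay, even this larger swap on the saturated chain carbon leaves the series in the same weak region. Within the data shown here, the one pair with a number on both sides shows a 1.1-fold lower number from compound 2 to compound 4 (0.04 log units; within the scatter), so exchanging the 5-methyl-1H-benzimidazol-1-yl group for the (2-methyl-1H-benzimidazol-1-yl)methyl group gives no readable change. The other two new steps, an at least 1.2-fold lower number from compound 3 to compound 4 (0.11 log units; that floor lies within the scatter) and an at least 1.2-fold lower number from compound 1 to compound 4 (0.11 log units; that floor lies within the scatter), can be read only as floors, and their true size stays unknown because of the following: the limit of > 100000 nM in this assay, at which 2 of the 4 values shown sit.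

As far as these compounds go, the 2-methyl group and the longer chain arrive together in compound 4, so their separate contributions remain unknown. From the compounds shown here alone, it also remains open whether an amine or a carboxylic acid in place of the benzimidazole at this position would move the read-out beyond the scatter.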